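Replacing 3-fluorophenyl with 4-methoxyphenyl in compound 3

This account rests on a few compounds, and the source may have more. Where it says the series, first, only, none or still open, it means among the compounds named here.

In a functional assay on HL-60 cells (Homo sapiens) for inhibition, read by MTT assay, with a stated time of 72 h (on this read-out higher numbers stand for weaker inhibition and lower numbers for stronger inhibition), compound 1 (`COc1cc(OC)cc(N2CCN(C(=O)c3onc(C)c3-c3ccccc3F)CC2)c1`) gives 165 nM. Compound 2 (`O=C(c1oc(C(F)(F)F)nc1-c1cccc(F)c1)N1CCN(c2cccc(Cl)c2)CC1`) is reported as "not active" (no number reported), with no number attached. Compound 3 (`Cc1nc(-c2cccc(F)c2)c(C(=O)N2CCN(c3cccc(Cl)c3)CC2)o1`) gives 33.7 nM, the lower of the two numbers available, and its gap to compound 1 lies beyond the usual scatter of repeat measurements.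

The untested compound 4 (`COc1ccc(-c2nc(C)oc2C(=O)N2CCN(c3cccc(Cl)c3)CC2)cc1`) keeps the rest of compound 3 and changes one group: 4-methoxyphenyl in place of 3-fluorophenyl on an aromatic carbon. In words, 4-methoxyphenyl stands in place of 3-fluorophenyl on an aromatic carbon.

Among the measured compounds shown here, no two measured compounds differ in a single place, so nothing here shows directly what this swap does in this assay. A modest rise in the number seems the most likely outcome, although a result within the scatter would be no surprise. For the measured compounds named here, compound 3 at 33.7 nM has the lowest number so far, and compound 2, reported as "not active" (no number reported), shows that a close relative can give no number at all. The expected change is a 1.8-fold higher number from compound 3 to compound 4 (0.25 log units; within the scatter), toward weaker inhibition, and this estimate is a loose one. For compound 4 the estimated value is 60 nM, with an expected range of 15 nM to 250 nM.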

Compound 4, half-maximal inhibitory concentration: "not active" (no number reported)
The entry for compound 4 holds no number; there is nothing to compare the estimate with.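

In this assay, among the compounds shown here, compound 4 gives "not active" (no number reported) and so offers no number to set against compound 3, which means no step between the two can be read. Nothing at hand accounts for this result. The compounds shown leave open how large a change 4-methoxyphenyl in place of 3-fluorophenyl brings on this shared core.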